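Ester to primary amide in the series

The compounds below may be only part of what the source reports. "The series", "measured", "known", "first", "only" and "open" are said of these compounds alone.

Compound 1, `CC(C)[C@H](C(=O)Nc1ncc(C(F)(F)F)s1)c1ccc(Cl)cc1`, in a functional assay on CHO cells for agonist activity at Free fatty acid receptor 2 (Homo sapiens), read by cAMP accumulation (a higher number here means a weaker inhibitor, a lower number a stronger inhibitor), gives 1500 nM.
Compound 2, `COC(=O)c1cnc(NC(=O)[C@H](c2ccc(Cl)cc2)C(C)C)s1`, in this assay gives 2000 nM.

Among the measured compounds shown here, compound 2 stands within the scatter of compound 1: the only measured step, a 1.3-fold higher number from compound 1 to compound 2 (0.12 log units; within the scatter), does not separate them. Compound 3, `CC(C)[C@H](C(=O)Nc1ncc(C(N)=O)s1)c1ccc(Cl)cc1`, differs from compound 2 by amino in place of methoxy on a carbonyl carbon. For the measured compounds named here, no measured step touches this carbonyl carbon; the one measured step concerns a group on the aromatic ring and does not bear on it. With nothing to draw on, no step beyond the scatter is expected in this assay, and the expected step is a 1.3-fold higher number from compound 2 to compound 3 (0.10 log units; within the scatter). Compound 3 is estimated at 2500 nM, with a range from 800 nM to 8000 nM.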

Compound 3, half-maximal inhibitory concentration: 71000 nM
Beside the measured number, compound 3's estimate is 28-fold (1.45 log units) below it; the measured number lies above the stated range.
By their numbers in this assay, from the lowest: compounds 1 and 2 (each within the scatter of the next); then compound 3.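

The group on this carbonyl carbon matters in this assay: amino in place of methoxy gives a 36-fold higher number from compound 2 to compound 3 (1.55 log units; beyond the scatter) while the earlier change from trifluoromethyl to methoxycarbonyl stayed within the scatter. Carbamoyl in place of trifluoromethyl gives a 47-fold higher number from compound 1 to compound 3 (1.68 log units; beyond the scatter) and shows that this aromatic carbon does not accept every group alike. No measurement here accounts for the drop in activity.

Open, on these data alone, is how a carboxylic acid or a nitrile in place of carbamoyl would read. A dimethylamide at the same carbonyl carbon would also test whether the step follows the amide hydrogens.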